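The source may hold more compounds than are shown below. What is called first, only, known or untested is meant among the compounds shown, and "the series" means these compounds.

The study looks at cytotoxicity in an ADME assay on PC-3 cells (Homo sapiens) for cytotoxicity, read by WST assay, tested at 100 uM (a lower number here means less inhibition, a higher number more inhibition at the concentration tested (going by the name of the read-out)), for a small set of anilides built on a shared core. Compound 1 `CSc1cccc(NC(=O)C2CCCN(C(=O)c3cc(C(F)(F)F)cc(C(F)(F)F)c3)C2)c1` gives 0% in this assay, the lower of the two numbers recorded so far. Its nearest neighbour is compound 2 `O=C(Nc1ccc(Cl)cc1)C1CCCN(C(=O)c2cccc(-c3cccs3)c2)C1`, which in this assay gives 4%; the two values lie within the usual scatter of each other, so neither compound can be said to be more or less cytotoxic than the other. Compound 3 `O=C(Nc1cccc(Oc2nccc(C(F)(F)F)c2Cl)c1)C1CCCN(C(=O)c2cc(C(F)(F)F)cc(C(F)(F)F)c2)C1` has not yet been measured. It differs from compound 1 in one place: (3-chloro-4-(trifluoromethyl)pyridin-2-yl)oxy in place of methylsulfanyl on an aromatic carbon. For the measured compounds named here, no step between two measured compounds is available for this kind of change, so the expectation rests only on the low readings of compound 1 and compound 2. The step from compound 1 to compound 3 is expected to be small, a number 8 percentage points higher from compound 1 to compound 3 (within the scatter), and not clearly beyond the scatter. Compound 3 is therefore estimated to give 8% in this assay, with a likely range from 0% to 30%.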

Compound 3, a percentage reported as inhibition, at one concentration (the size of the read-out at that concentration, not a potency): 0%
Compound 3: middle estimate off by 8 percentage points, on the high side, and the stated range covers the measured number.
By their numbers in this assay, from the lowest: compounds 1, 3 and 2 (each within the scatter of the next).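

In this assay the step of replacing methylsulfanyl with (3-chloro-4-(trifluoromethyl)pyridin-2-yl)oxy on this aromatic carbon, meta to a large group, reads as no change at the digits printed from compound 1 to compound 3 (within the scatter) and so gives the first direct view of a change at this position. Going from 2 heavy atoms and no ring to 12 heavy atoms and a six-membered aromatic ring with 1 hetero atom thus leaves the reading where it stood, which the earlier compounds, with no step between them, could not show. Nothing available bears on why the reading holds across this change.

Going by these compounds, whether a primary amine, a carboxylic acid or a simple methoxy group at this position would also leave the reading unmoved remains open. So does whether any group placed here can lift the reading beyond the scatter.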